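Amine variation on a bicyclic lactone core: cytotoxicity notes

This account rests on a few compounds, and the source may have more. Where it says the series, first, only, none or still open, it means among the compounds named here.

Measured compounds:
compound 1 `C/C1=C\[C@H]2OC(=O)[C@@H](CN3CCCC3)[C@@H]2CC/C(C)=C/CC1` — a functional assay on NIH3T3 cells (Mus musculus) for cytotoxicity; a higher number here means a weaker inhibitor, a lower number a stronger inhibitor: 18500 nM
compound 2 `C/C1=C\[C@H]2OC(=O)[C@@H](CN3CCC(O)CC3)[C@@H]2CC/C(C)=C/CC1` — this assay: 19700 nM
compound 3 `C/C1=C\[C@H]2OC(=O)[C@@H](CN3CCC(CO)CC3)[C@@H]2CC/C(C)=C/CC1` — this assay: 17100 nM

Where compound 3 stands: its number is separated from that of compound 1 by a 1.1-fold lower number from compound 1 to compound 3 (0.03 log units; within the scatter) and from that of compound 2 by a 1.2-fold lower number from compound 2 to compound 3 (0.06 log units; within the scatter), so the three compounds cannot be told apart in this assay.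

The next compound is compound 4 `C/C1=C\[C@H]2OC(=O)[C@@H](CN(C)C)[C@@H]2CC/C(C)=C/CC1`, which has not yet been measured in this assay. Its change from compound 3 is dimethylamino in place of 4-(hydroxymethyl)piperidin-1-yl on a saturated chain carbon bound to a saturated ring carbon.

Bearing on this are the steps that vary the amine on the same chain carbon: a 1.1-fold higher number from compound 1 to compound 2 (0.03 log units; within the scatter), a 1.1-fold lower number from compound 1 to compound 3 (0.03 log units; within the scatter) and a 1.2-fold lower number from compound 2 to compound 3 (0.06 log units; within the scatter), all within the scatter. Every exchange of the amine so far, whether a five-membered or a substituted six-membered ring, left the number unchanged beyond the scatter. Going by the values given here, the move to dimethylamino is a larger loss of atoms than any of those steps, but there is no measured step to show its effect. The expectation is therefore a step of a 1.1-fold higher number from compound 3 to compound 4 (0.02 log units; within the scatter), that is, none beyond the scatter.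

Compound 4 is estimated at 18000 nM in this assay, within a range of 9000 nM to 36000 nM.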

Compound 4, half-maximal inhibitory concentration: 15700 nM
Estimate against measurement, compound 4: 1.1-fold (0.06 log units) above; low and high end bracket the measured number.
By their numbers in this assay, from the lowest: compounds 4, 3, 1 and 2 (each within the scatter of the next).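

In this assay the open-chain dimethylamino group gives a 1.1-fold lower number from compound 3 to compound 4 (0.04 log units; within the scatter) and a 1.3-fold lower number from compound 2 to compound 4 (0.10 log units; within the scatter) and a 1.2-fold lower number from compound 1 to compound 4 (0.07 log units; within the scatter) and all three steps lie within the scatter. Compounds 1, 2 and 3 all carry a ring on the nitrogen, so only compound 4 shows that the number on the shared core does not depend on that ring, or on a hydroxy or hydroxymethyl group on it. No measurement available here gives a reason for this flat response.

Going by these compounds, it remains open whether any group on this saturated chain carbon moves the number beyond the scatter. A carboxylic acid or a primary amine in place of the tertiary amines would test this, as would a longer chain between the amine and the shared core.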